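The compounds below may be only part of what the source reports. "The series", "measured", "known", "first", "only" and "open" are said of these compounds alone.

Measured so far in an assay on isolated protein for inhibition of Dipeptidyl peptidase 9 (Homo sapiens); a lower number here means a stronger inhibitor, a higher number a weaker inhibitor:
compound 1 `N[C@@H]1CCCN(c2cc(Nc3ccccc3Cl)n3nccc3n2)C1`: > 100000 nM
compound 2 `Clc1ccc(Nc2cc(N3CCNCC3)nc3ccnn23)c(Cl)c1`: > 100000 nM
compound 3 `Fc1ccc(CNc2cc(N3CCNCC3)nc3ccnn23)c(F)c1`: > 50000 nM

Compound 1 gives only a limit of the assay in this assay, not a number. Compound 2 likewise stops at a limit. Compound 3 also reaches only a limit. Two of the three values sit at the limit of > 100000 nM in this assay, at which 2 of the 3 values shown sit, and one at the limit of > 50000 nM in this assay, at which 1 of the 3 values shown sits, so nothing in this set gives a measured step, and where compound 1 stands can be said only as a limit.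

Compound 4 `Cc1ccc(Nc2cc(N3CCC[C@@H](N)C3)nc3ccnn23)c(C)c1` differs from compound 1 by 2,4-dimethylphenyl in place of 2-chlorophenyl on a nitrogen on an aromatic ring. Among the measured compounds shown here, no step between measured compounds is available, so the size of this step cannot be read from the numbers; compound 1 is itself only a limit. The step from compound 1 to compound 4 is expected to be a number no higher from compound 1 to compound 4 (the limit leaves the size open), none beyond the scatter, with a further limit the likeliest outcome. Compound 4 is expected at 100000 nM, between 30000 nM and 500000 nM.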

Compound 4, half-maximal inhibitory concentration: > 100000 nM
Compound 4 gave a limit, no number (the forecaster's own chance of this, stated with the estimate: 85%); the middle value sits exactly at the limit.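

Compound 1 and compound 4 both stop at a limit of the assay, and the step between them cannot be read. The compounds shown leave open whether any change on the shared core gives a measurable inhibition.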